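The source may report more compounds than this note shows. Statements on the series, on what has been measured and on what is new or still open speak of the compounds shown alone.

Measured so far in an assay on isolated protein for binding affinity to Melanocortin receptor 4 (Homo sapiens); on this read-out higher numbers stand for weaker inhibition and lower numbers for stronger inhibition:
compound 1 `CCn1ccnc1-c1cccc(Cl)c1CCc1cc(Br)ccc1OC` gives 310 nM
compound 2 `CCCn1ccnc1-c1cccc(Cl)c1CCc1cc(Br)ccc1OC` gives 1300 nM

Among the measured compounds shown here, compound 2 stands with the higher of the two numbers; its only neighbour is compound 1, and the step of a 4.2-fold higher number from compound 1 to compound 2 (0.62 log units; beyond the scatter) is the whole of the measured record.

Compound 3 `COc1ccc(Br)cc1CCc1c(Cl)cccc1-c1ncc2n1CCCC2` is the next candidate. Relative to compound 2 the change is a group of 9 heavy atoms (7 carbon, 2 nitrogen; one five-membered aromatic ring with 2 hetero atoms, one six-membered non-aromatic ring with 1 hetero atom) in place of a group of 8 heavy atoms (6 carbon, 2 nitrogen; one five-membered aromatic ring with 2 hetero atoms), on an aromatic carbon. In effect the open chain on the imidazole nitrogen of compound 2 is closed back onto the imidazole carbon to give a fused saturated ring; the count of heavy atoms rises by one.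

For the measured compounds named here, the single measured step, from compound 1 to compound 2, concerns chain lengthening at that nitrogen and weakened binding by a modest amount. It does not cover ring closure, so it bears on the new change only indirectly: it shows that this region of compound 2 is sensitive to small additions, without saying in which direction a cyclised group would move. The expectation is therefore broad, centred close to compound 2, with the step of a 1.4-fold lower number from compound 2 to compound 3 (0.16 log units; within the scatter) expected to remain small in this assay. Compound 3 is estimated at 900 nM, within a range of 200 nM to 4000 nM.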

Compound 3, inhibition constant: 340 nM
Estimate against measurement, compound 3: 2.6-fold (0.42 log units) above; the range from low to high includes it.
By their numbers in this assay, from the lowest: compounds 1 and 3 (each within the scatter of the next); then compound 2.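

In this assay the number at this position does not simply rise with the size of the group: closing the propyl chain back onto the imidazole carbon gives a 3.8-fold lower number from compound 2 to compound 3 (0.58 log units; beyond the scatter) and so reverses the loss seen on chain lengthening, although the entering group has the most heavy atoms of the three. The step of a 1.1-fold higher number from compound 1 to compound 3 (0.04 log units; within the scatter) puts the fused group level with the ethyl-bearing group of compound 1, so this position accepts the extra heavy atoms when they are tied into a ring, and compound 2 is the one that stands apart in this small set. Nothing on hand gives a reason why the closed ring and the open propyl chain read differently.

Still open, as far as these compounds go, is whether the fused six-membered ring is the best closure, or whether a smaller five-membered fused ring or a larger seven-membered one would read the same. Also open, from the compounds shown here alone, is how a branched isopropyl group or a longer butyl chain would compare with propyl, and whether an amine or a hydroxyl on the saturated ring would be accepted.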